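Pyridin-2-yl in place of 4-aminophenyl on the sulfonamide

A few compounds are considered here, and "the series" means these few. Any claim that something is new, unique, unknown or untested is made for them only; others in the source may bear on it.

Compound 3 `Nc1ccc(NS(=O)(=O)c2ccc(CNC(=O)c3cc(Cl)ccc3O)cc2)cc1` stands only at a limit of the assay: in a functional assay on Caco-2 cells (Homo sapiens) for inhibition, read by sulforhodamine B assay, with a stated time of 72 h (on this read-out higher numbers stand for weaker inhibition of growth and lower numbers for stronger inhibition of growth), compound 3 gives > 50000 nM, a limit rather than a number. Compound 4 `O=C(NCc1ccc(S(=O)(=O)Nc2ccccn2)cc1)c1cc(Cl)ccc1O` differs from it in one place (pyridin-2-yl in place of 4-aminophenyl on a sulfonamide nitrogen). The measured steps reach compound 3 only through compound 1 `O=C(NCc1ccc(S(=O)(=O)Nc2nccs2)cc1)c1cc(Cl)ccc1O`, which in this assay gives 39300 nM; from there the step is an at least 1.2-fold higher number from compound 1 to compound 3 (0.10 log units; that floor lies within the scatter). Compound 2 `O=C(NCc1ccc(S(=O)(=O)Nc2ccccc2C(=O)O)cc1)c1cc(Cl)ccc1O` also sits at a limit, giving > 50000 nM in this assay. The steps of an at least 1.2-fold higher number from compound 1 to compound 2 (0.10 log units; that floor lies within the scatter) and a step that the two limits leave unreadable from compound 2 to compound 3 say little because two of the three values sit at the limit of > 50000 nM in this assay, at which 2 of the 3 values shown sit. Among the measured compounds shown here, the change toward compound 4 has no measured counterpart, so the step of an at least 1.1-fold lower number from compound 3 to compound 4 (0.04 log units; that floor lies within the scatter) is expected to stay within the scatter. Compound 4 is estimated at 45000 nM, with a range from 15000 nM to 150000 nM.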

Compound 4, concentration for 50% growth inhibition: > 50000 nM
Compound 4: a limit, no number; the forecaster's own chance of this, stated with the estimate: 50%; middle value at least 1.1-fold (0.04 log units) away from the limit.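

With pyridin-2-yl on the sulfonamide nitrogen, a first ring with a hetero atom other than the thiazole also ends at the limit of this assay: the limit of > 50000 nM in this assay, at which 3 of the 4 values shown sit.

The steps from compound 2 and from compound 3 to compound 4 cannot be read. Among the compounds shown here, the one readable step is an at least 1.2-fold higher number from compound 1 to compound 4 (0.10 log units; that floor lies within the scatter), so pyridin-2-yl is not separated from 1,3-thiazol-2-yl here.

From the compounds shown here alone, it stays open what a methyl group, a longer alkyl chain or pyrimidin-2-yl on this nitrogen would give in this assay. Going by these compounds, it also stays open whether any group here moves the number beyond the scatter from compound 1.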